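Hydroxy for ethyl, two bonds along the chain from sulfur

The source may report more compounds than this note shows. Statements on the series, on what has been measured and on what is new or still open speak of the compounds shown alone.

Compound 1 `CC1(C)CC(=O)C(C(=S)SCCO)=C(Nc2ccc(Cl)cc2Cl)C1`: in a functional assay on cells (blood, Homo sapiens) for inhibition, read by chemiluminescence, with a stated time of 30 min (a lower number here means a stronger inhibitor, a higher number a weaker inhibitor), compound 1 gives > 100 ug/mL, a limit of the assay.
Compound 2 `CC1(C)CC(=O)C=C(Nc2ccc(Cl)cc2)C1`: compound 2 gives > 100 ug/mL, a limit.
Compound 3 `CCCCSC(=S)C1=C(Nc2ccc(Cl)cc2)CC(C)(C)CC1=O`: compound 3 gives > 100 ug/mL, a limit.

Compound 3 stands at the limit of > 100 ug/mL in this assay, at which 3 of the 3 values shown sit; no number is known for it. Among the compounds with values here, the only measured step that touches it is a step that the two limits leave unreadable from compound 2 to compound 3, and both ends being limits, its size cannot be read. Compound 4 `CC1(C)CC(=O)C(C(=S)SCCO)=C(Nc2ccc(Cl)cc2)C1` differs from compound 3 by hydroxy in place of ethyl on a saturated chain carbon, two bonds along the chain from a sulfur. Compound 1, which already carries the (2-hydroxyethyl)sulfanyl chain, also sits at the limit. Within the data shown here, no step in this assay is readable, so no direction can be drawn; compound 4 is therefore expected to remain at the limit as well, the step that the limit leaves unreadable from compound 3 to compound 4 being an estimate only. Compound 4 is estimated at 200 ug/mL, between 100 ug/mL and 1000 ug/mL.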

Compound 4, half-maximal inhibitory concentration: > 100 ug/mL
Compound 4: only a limit was reported; the forecaster's own chance of this, stated with the estimate: 85%; the middle value lies beyond the limit too.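

In this assay, within the data shown here, compound 1, compound 2, compound 3 and compound 4 all give only a limit, so no step among them can be read: the limit of > 100 ug/mL in this assay, at which 4 of the 4 values shown sit.
The compounds shown leave open whether any change to the shared core or its chain gives a measurable inhibition.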